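A few compounds are considered here, and "the series" means these few. Any claim that something is new, unique, unknown or untested is made for them only; others in the source may bear on it.

Measured so far:
Compound 1, `OCCNC(=S)Nc1ccccc1` — in a functional assay on RAW264.7 cells (Mus musculus) for inhibition, read by Griess assay, with a stated time of 24 h (on this read-out lower numbers stand for stronger inhibition and higher numbers for weaker inhibition), compound 1 gives >= 200000 nM, which is a limit of the assay and not a number.
Compound 2, `COc1ccc(NC(=S)NCc2ccccc2)cc1` — in this assay compound 2 gives >= 200000 nM, again a limit of the assay rather than a number.

On the numbers shown, compound 2 stands nowhere distinct: both recorded values sit at the same point, (the limit of >= 200000 nM in this assay, at which 2 of the 2 values shown sit), so no ordering between compound 1 and compound 2 can be read, and no step between measured compounds is available.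

Compound 3, `CC(C)c1ccc(NC(=S)NCc2ccccc2)cc1`, is not yet measured in this assay. It differs from compound 2 in one place: isopropyl in place of methoxy on an aromatic carbon. Among the measured compounds shown here, with nothing beyond limits to anchor a trend, no step beyond the usual scatter is expected here; the series so far gives no sign that this exchange on the aromatic carbon moves the read-out.

Compound 3 is therefore expected to come out at about 200000 nM, within a range of 100000 nM to 400000 nM. The expected step is a number no higher from compound 2 to compound 3 (the limit leaves the size open), that is, most likely another reading at the limit of the assay.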

Compound 3, half-maximal inhibitory concentration: 2400 nM
Compound 3: the middle estimate sits 83-fold (1.92 log units) above what was measured; the measured number lies below the stated range.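

Isopropyl in place of methoxy on an aromatic carbon, para to a large group, gives an at least 83-fold lower number from compound 2 to compound 3 (1.92 log units; beyond the scatter) in this assay. Among the compounds shown here, this position can therefore move the read-out strongly, which the earlier compounds could not show, and compound 3 is the first to give a number rather than a limit. The true size of the step stays open, as it is measured from a limit of the assay and not from a number: the limit of >= 200000 nM in this assay, at which 2 of the 3 values shown sit.

A single exchange changes several counted features together: the oxygen and its hydrogen-bond acceptor leave, and the heavy-atom count rises, so the compounds shown do not separate these. Nor do they show how a tert-butyl group, an ethyl group or an amine on the same aromatic carbon would read.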